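The source may report more compounds than this note shows. Statements on the series, on what has been measured and on what is new or still open speak of the compounds shown alone.

Compound 1 `CCCCCCCCCCCCNC(=O)[C@@H](NC(=O)/C=C/c1ccccc1)[C@@H](C)O` was tested in a functional assay on MCF7 cells (Homo sapiens) for cytotoxicity, read by MTT assay, with a stated time of 48 h; on this read-out lower numbers stand for stronger inhibition and higher numbers for weaker inhibition. In this assay compound 1 gives only a limit, > 200000 nM, and not a number. Compound 2 `C/C=C/C=C/C(=O)N[C@H](C(=O)NCCCCCCCCCCCC)[C@@H](C)O` gives 37100 nM in this assay, and compound 3 `CCCCCCCCCCCCNC(=O)[C@@H](NS(=O)(=O)c1ccc(C)cc1)[C@@H](C)O` gives 31100 nM. The two numbers sit close together: a 1.2-fold lower number from compound 2 to compound 3 (0.08 log units; within the scatter). Against the limit of compound 1 (the limit of > 200000 nM in this assay, at which 1 of the 3 values shown sits), both the change to compound 2 and the change to compound 3 read as real moves, an at least 5.3-fold lower number from compound 1 to compound 2 (0.73 log units; beyond the scatter) and an at least 6.4-fold lower number from compound 1 to compound 3 (0.80 log units; beyond the scatter). So compound 3 stands with compound 2 at the measured end of this small set, while the third value is a limit.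

Compound 4 `CCCCCCCCCCCCCCNC(=O)[C@@H](NS(=O)(=O)c1ccc(C)cc1)[C@@H](C)O` differs from compound 3 in one place: ethyl in place of hydrogen on a saturated chain carbon, ten or more bonds along the chain from an amide-type nitrogen. Going by the values given here, none of the measured steps touches this part of the molecule; all three exchange the group on the amine nitrogen and leave the saturated chain as it is. Among the compounds with values here, there is thus no measured step that bears on lengthening the chain, and with the two remaining numbers within the scatter of each other, a change of no more than the usual scatter is expected in this assay. The step from compound 3 to compound 4 is estimated as a 1.1-fold lower number from compound 3 to compound 4 (0.05 log units; within the scatter). Compound 4 is therefore expected to give about 28000 nM in this assay, with a range from 9000 nM to 90000 nM.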

Compound 4, half-maximal inhibitory concentration: 12900 nM
Compound 4: middle estimate off by 2.2-fold (0.34 log units), on the high side, and the stated range covers the measured number.
By their numbers in this assay, from the lowest: compound 4; then compounds 3 and 2 (each within the scatter of the next). At a limit, above all of these: compound 1.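

Compound 4 shows that the saturated chain on the amide-type nitrogen is not a silent part of the molecule. Going by these compounds alone, with (4-methylphenyl)sulfonyl kept on the amine nitrogen, ethyl in place of hydrogen on a saturated chain carbon, ten or more bonds along the chain from an amide-type nitrogen, gives in this assay a 2.4-fold lower number from compound 3 to compound 4 (0.38 log units; beyond the scatter), a modest step beyond the scatter, whereas all the earlier steps exchanged the group on the amine nitrogen and left this chain as it was. Nothing measured in this set gives a reason for this step.

This single pair leaves open whether the same change would carry over with (penta-1,3-dien-1-yl)carbonyl or (2-phenylethenyl)carbonyl on the amine nitrogen in place of (4-methylphenyl)sulfonyl. It also leaves open how the number would run with a still longer chain, a shorter chain, or a chain ending in an amine or a carboxylic acid, and whether the step seen on these cells holds in any other cell line.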